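A few compounds are considered here, and "the series" means these few. Any claim that something is new, unique, unknown or untested is made for them only; others in the source may bear on it.

Three compounds share one core and differ only in the aromatic group attached to an amide-type nitrogen. Compound 1 `CN1C[C@H](C(=O)Nc2ccc(C(F)(F)F)cc2)[C@@H](c2ccc(/C=C/C(=O)Nc3ccccc3N)cc2)C1` carries a 4-(trifluoromethyl)phenyl there; in an in vitro ADME assay on microsomes from liver (Mus musculus) for pharmacokinetics, read by LC-MS, with a stated time of 10 min, tested at 1 uM (a higher number here means faster removal of the compound, a lower number slower removal), compound 1 gives 23 mL/min/kg. Compound 2 `CN1C[C@H](C(=O)Nc2ccc(F)c(Cl)c2)[C@@H](c2ccc(/C=C/C(=O)Nc3ccccc3N)cc2)C1` carries a 3-chloro-4-fluorophenyl instead, and in this assay compound 2 gives 34 mL/min/kg. Compound 3 `CN1C[C@H](C(=O)Nc2ccc(F)cc2F)[C@@H](c2ccc(/C=C/C(=O)Nc3ccccc3N)cc2)C1` carries a 2,4-difluorophenyl, and compound 3 gives 27 mL/min/kg.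

Compound 1 has the lowest of the three numbers, but the differences are small: there is a 1.5-fold higher number from compound 1 to compound 2 (0.17 log units; within the scatter) and a 1.2-fold higher number from compound 1 to compound 3 (0.07 log units; within the scatter), and between the other two there is a 1.3-fold lower number from compound 2 to compound 3 (0.10 log units; within the scatter). None of these swaps of one substituted phenyl for another moves the clearance beyond the usual scatter.

Compound 4 `CN1C[C@H](C(=O)Nc2ccccn2)[C@@H](c2ccc(/C=C/C(=O)Nc3ccccc3N)cc2)C1` is not yet measured. Its difference from compound 1 is pyridin-2-yl in place of 4-(trifluoromethyl)phenyl on an amide-type nitrogen. This is a different kind of change from the three measured ones, which only exchanged substituents on a phenyl ring, so they bear on it only loosely; all three stayed within the scatter. On that basis the step is expected to be a 1.2-fold higher number from compound 1 to compound 4 (0.09 log units; within the scatter), with no clear direction. Compound 4 is therefore estimated to give 28 mL/min/kg, within a range of 14 mL/min/kg to 56 mL/min/kg.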

Compound 4, clearance: 40 mL/min/kg
Compound 4: middle estimate off by 1.4-fold (0.15 log units), on the low side; measured number inside the range.
By their numbers in this assay, from the lowest: compounds 1, 3, 2 and 4 (each within the scatter of the next).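

The first three compounds only exchanged substituents on a phenyl ring, whereas compound 4 shows that this amide-type nitrogen can carry a different aromatic ring, one with a hetero atom and a hydrogen-bond acceptor and without the trifluoromethyl group, and the clearance in this assay still stays within the scatter of all three phenyl compounds (a 1.7-fold higher number from compound 1 to compound 4 (0.24 log units; within the scatter); a 1.5-fold higher number from compound 3 to compound 4 (0.17 log units; within the scatter); a 1.2-fold higher number from compound 2 to compound 4 (0.07 log units; within the scatter)). Across these four compounds, then, neither the substituents on the ring nor the change from a carbon-only ring to pyridin-2-yl separates one clearance clearly from another, so none of these groups can be singled out as giving faster or slower removal. No separate measurement is available here that could explain the small differences that do appear.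

Every group shown on this nitrogen is a six-membered aromatic ring, so it remains open whether a plain phenyl, a cyclohexyl group, or a chain ending in an amine or a carboxylic acid would stay within the scatter as well. Going by these compounds, it is also open whether a change elsewhere on the shared core, such as an ethyl group in place of its methyl group, would shift the clearance more.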